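A Second Chloro Added to a Weak Inhibitor

A few compounds are considered here, and "the series" means these few. Any claim that something is new, unique, unknown or untested is made for them only; others in the source may bear on it.

Measured compounds:
compound 1 `Cc1ccc(-c2csc(N/N=C/c3ccc(N4CCCC4)cc3)n2)cc1` — in an assay on isolated protein for inhibition of Amine oxidase [flavin-containing] A (Homo sapiens), read by fluorescence and Amplex Red, with a stated time of 30 min (on this read-out lower numbers stand for stronger inhibition and higher numbers for weaker inhibition), compound 1 gives 20000 nM
compound 2 `N#Cc1ccc(-c2csc(N/N=C/c3ccc(N4CCCC4)cc3)n2)cc1` — compound 2 gives 66300 nM
compound 3 `Clc1ccc(-c2csc(N/N=C/c3ccc(N4CCCC4)cc3)n2)cc1` — compound 3 gives 45200 nM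

Compound 3 holds the second highest number of the three: the step of a 2.3-fold higher number from compound 1 to compound 3 (0.35 log units; beyond the scatter) lies beyond the scatter, while the step of a 1.5-fold lower number from compound 2 to compound 3 (0.17 log units; within the scatter) does not. Compound 4 `Clc1ccc(-c2csc(N/N=C/c3ccc(N4CCCC4)cc3)n2)c(Cl)c1` differs from compound 3 by chloro in place of hydrogen on an aromatic carbon. Among the measured compounds shown here, no measured step adds a group to a ring that already carries one; the closest guide is a 2.3-fold higher number from compound 1 to compound 3 (0.35 log units; beyond the scatter), where a chloro on this ring gave a higher number than methyl. Lacking a step of the same kind, a step of a 1.0-fold lower number from compound 3 to compound 4 (0.00 log units; within the scatter) is expected, within the scatter. Compound 4 is therefore estimated at 45000 nM, with a range from 15000 nM to 135000 nM.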

Compound 4, half-maximal inhibitory concentration: 103000 nM
Beside the measured number, compound 4's estimate is 2.3-fold (0.36 log units) below it, within the range that was stated.
By their numbers in this assay, from the lowest: compound 1; then compounds 3, 2 and 4 (each within the scatter of the next, the first and the last beyond it).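

On a ring that already carries a chloro, a second chloro ortho to a large group still moves the result: the step is a 2.3-fold higher number from compound 3 to compound 4 (0.36 log units; beyond the scatter), so inhibition weakens. The two wider comparisons put this in context, with a 1.6-fold higher number from compound 2 to compound 4 (0.19 log units; within the scatter) and, the largest step of the set, a 5.2-fold higher number from compound 1 to compound 4 (0.71 log units; beyond the scatter) on the same read-out. No measurement shown gives a reason for this effect.

As far as these compounds go, whether a fluoro or a methoxy group on the same carbon would also raise the number stays open. So does whether a chloro there would do the same on the 4-methylphenyl ring.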